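Swapping One Five-Membered Ring for Another in Cytotoxicity

This account rests on a few compounds, and the source may have more. Where it says the series, first, only, none or still open, it means among the compounds named here.

Compound 2 `Oc1ccc(-c2cc(-c3ccco3)nc(-c3ccccc3Cl)c2)cc1` was tested in an ADME assay on HEK293 cells (Homo sapiens) for cytotoxicity, read by CCK-8 assay and cell counting, with a stated time of 2 days (a higher number here means a weaker inhibitor, a lower number a stronger inhibitor), and compound 2 gives 4310 nM. Going by the values given here, this is the lowest of the three numbers measured so far. Its nearest neighbour is compound 1 `Oc1ccc(-c2cc(-c3cccs3)nc(-c3ccccc3Cl)c2)cc1`, which in this assay gives 5220 nM. The measured step of a 1.2-fold lower number from compound 1 to compound 2 (0.08 log units; within the scatter) is within the scatter. Furthest away is compound 3 `Oc1cccc(-c2cc(-c3ccc(Cl)cc3)nc(-c3cccnc3)c2)c1`, which in this assay gives 39500 nM; no single step links it to compound 2, and the two numbers differ beyond the scatter.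

Compound 4 `Oc1ccc(-c2cc(-c3ccsc3)nc(-c3ccccc3Cl)c2)cc1` differs from compound 2 by thiophen-3-yl in place of furan-2-yl on an aromatic carbon. Among the compounds with values here, the only measured step that bears on this kind of change is the exchange of one five-membered aromatic ring for another, a 1.2-fold lower number from compound 1 to compound 2 (0.08 log units; within the scatter), which did not move the number beyond the scatter. On that basis no step beyond the scatter is expected in this assay, in either direction. Compound 4 is therefore expected to give 5000 nM in this assay, with a range from 2500 nM to 10000 nM. The step implied by this estimate, a 1.2-fold higher number from compound 2 to compound 4 (0.06 log units; within the scatter), is expected to lie within the scatter.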

Compound 4, half-maximal inhibitory concentration: 5930 nM
The estimate for compound 4 lay 1.2-fold (0.07 log units) below the measured number; the measured number falls inside the stated range.
By their numbers in this assay, from the lowest: compounds 2, 1 and 4 (each within the scatter of the next); then compound 3.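

Within this assay, the step of a 1.1-fold higher number from compound 1 to compound 4 (0.06 log units; within the scatter) moves the attachment of the thiophene ring at the carbon next to the ring nitrogen, a kind of change the earlier compounds did not include. The step of a 1.4-fold higher number from compound 2 to compound 4 (0.14 log units; within the scatter) changes the ring's hetero atom and its point of attachment together, and this combined exchange also stays within the scatter. Among furan-2-yl, thiophen-2-yl and thiophen-3-yl, then, neither the exchange of oxygen for sulfur nor the shift in attachment separates the compounds in this assay, and the data shown offer no explanation for why the three read alike.

As far as these compounds go, all three groups are five-membered aromatic rings with 1 hetero atom, so it remains open whether this tolerance extends to a different kind of group at this position, such as an amine, a carboxylic acid or a longer alkyl chain. The 2-chlorophenyl and 4-hydroxyphenyl groups are the same throughout these three compounds, which also leaves open whether the same result would hold with other groups in their places.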